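Two hydroxyls in place of a methoxy on the benzyl arm

The compounds below may be only part of what the source reports. "The series", "measured", "known", "first", "only" and "open" are said of these compounds alone.

Measured compounds:
- compound 1, `COc1ccccc1CNc1ncnc2c1ncn2[C@@H]1O[C@H](CO)[C@@H](O)[C@H]1O`, 89000 nM
- compound 2, `COc1cccc(CNc2ncnc3c2ncn3[C@@H]2O[C@H](CO)[C@@H](O)[C@H]2O)c1`, > 166000 nM
- compound 3, `OC[C@H]1O[C@@H](n2cnc3c(NCc4ccc(F)cc4Cl)ncnc32)[C@H](O)[C@@H]1O`, 15600 nM

In a functional assay on K562 cells (Homo sapiens) for antiproliferative activity, with a stated time of 72 h (a higher number here means a weaker inhibitor, a lower number a stronger inhibitor), compound 1 gives 89000 nM. Of the two plain numbers shown, compound 1 has the higher one; compound 3 sits a 5.7-fold lower number from compound 1 to compound 3 (0.76 log units; beyond the scatter) away. For compound 2 the assay reports only a limit, (the limit of > 166000 nM in this assay, at which 1 of the 3 values shown sits), so the step of an at least 1.8-fold higher number from compound 1 to compound 2 (0.27 log units; that floor lies within the scatter) has a floor that lies within the scatter.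

Compound 4, `OC[C@H]1O[C@@H](n2cnc3c(NCc4cccc(O)c4O)ncnc32)[C@H](O)[C@@H]1O`, is not yet measured. It differs from compound 1 by 2,3-dihydroxyphenyl in place of 2-methoxyphenyl on a saturated chain carbon bound to a nitrogen on an aromatic ring. Among the measured compounds shown here, no measured step changes the benzyl ring in this way. The step from compound 1 to compound 2 moves the methoxy to another position and gives at most a small change; the step from compound 1 to compound 3 exchanges the methoxy for a chloro and a fluoro and gives a 5.7-fold lower number from compound 1 to compound 3 (0.76 log units; beyond the scatter). Neither step adds hydroxyls, so the direction for compound 4 is open. The estimate for compound 4 is therefore a number near that of compound 1, with a wide range: 100000 nM, between 30000 nM and 300000 nM, which is the expected step of a 1.1-fold higher number from compound 1 to compound 4 (0.05 log units; within the scatter).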

Compound 4, half-maximal inhibitory concentration: 25800 nM
Compound 4: middle estimate off by 3.9-fold (0.59 log units), on the high side; the whole stated range lies above it.
By their numbers in this assay, from the lowest: compounds 3 and 4 (each within the scatter of the next); then compound 1. At a limit, above all of these: compound 2.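

In this assay, among the compounds shown here, the change to 2,3-dihydroxyphenyl is the first at this position to bring in hydrogen-bond donors, and it gives a 3.4-fold lower number from compound 1 to compound 4 (0.54 log units; beyond the scatter), so a ring carrying hydroxyls is compatible with a move beyond the scatter, in the same direction as the earlier exchange for 2-chloro-4-fluorophenyl. The direct comparison of these two rings gives a 1.7-fold higher number from compound 3 to compound 4 (0.22 log units; within the scatter), so the assay does not tell them apart, and among the compounds shown a halogenated ring is not the only kind found at this level. The step from the 3-methoxyphenyl ring reads an at least 6.4-fold lower number from compound 2 to compound 4 (0.80 log units; beyond the scatter), which is only a floor, as compound 2 is known only by a limit: the limit of > 166000 nM in this assay, at which 1 of the 4 values shown sits.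

The compounds shown do not separate the two hydroxyls from each other, so it remains open whether a ring with a single hydroxyl, or with an amine in its place, would give the same step. Going by these compounds, it is also open whether the 2,3-dihydroxybenzyl arm would give a similar step on a different core.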